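Moving the trifluoromethyl group on compound 2

A few compounds are considered here, and "the series" means these few. Any claim that something is new, unique, unknown or untested is made for them only; others in the source may bear on it.

Within the data shown here, in a functional assay on HCT-116 cells (Homo sapiens) for antiproliferative activity, read by MTT assay, with a stated time of 24 h (a lower number here means a stronger inhibitor, a higher number a weaker inhibitor), compound 2 `COc1cc(OC)c(-c2coc3cc(OCc4ccc(C(F)(F)F)cc4)ccc3c2=O)cc1OC` gives 2440 nM, the only true number so far. Compound 1 `COc1cc(OC)c(-c2coc3cc(OCC(=O)c4cccc(C(F)(F)F)c4)ccc3c2=O)cc1OC` gives > 10000 nM, which is a limit and not a number.

Compound 3 `COc1cc(OC)c(-c2coc3cc(OCc4cccc(C(F)(F)F)c4)ccc3c2=O)cc1OC` keeps the atoms of compound 2 but joins them differently: 3-(trifluoromethyl)phenyl in place of 4-(trifluoromethyl)phenyl on a saturated chain carbon bound to an oxygen on an aromatic ring. Among the measured compounds shown here, the one measured step, an at least 4.0-fold lower number from compound 1 to compound 2 (0.61 log units; beyond the scatter), lies beyond the scatter. However, it removes a carbonyl as well as exchanging the aryl group, so it says little about this exchange alone. Compound 1 does carry the 3-(trifluoromethyl)phenyl group, which leaves a weaker result possible.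

With so little evidence, only a small change is expected in this assay, within the scatter: a 1.2-fold higher number from compound 2 to compound 3 (0.09 log units; within the scatter). For compound 3 the estimated value is 3000 nM, with an expected range from 1000 nM to 9000 nM.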

Compound 3, half-maximal inhibitory concentration: 3400 nM
For compound 3 the middle estimate is 1.1-fold (0.05 log units) below the measured one; measured number inside the range.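

In this assay, exchanging 4-(trifluoromethyl)phenyl for 3-(trifluoromethyl)phenyl gives a 1.4-fold higher number from compound 2 to compound 3 (0.14 log units; within the scatter), so this move of the trifluoromethyl group does not separate the two compounds. With the 3-(trifluoromethyl)phenyl group now the same on both sides, the carbonyl can be read on its own: removing it gives an at least 2.9-fold lower number from compound 1 to compound 3 (0.46 log units; beyond the scatter), so the weak result of compound 1 goes with the carbonyl and not with where the trifluoromethyl group sits. Compound 1 stands at a limit and not at a true number, so this step gives only a minimum size: the limit of > 10000 nM in this assay, at which 1 of the 3 values shown sits.

The compounds shown leave open whether a nitrile or an amine in place of the trifluoromethyl group would shift the number beyond the scatter. They also leave open how a longer chain carrying the same 3-(trifluoromethyl)phenyl group would read.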